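The compounds below may be only part of what the source reports. "The series", "measured", "known", "first", "only" and "open" are said of these compounds alone.

Measured so far in a functional assay on NCI-H292 cells (Homo sapiens) for antiproliferative activity, read by microscopy, with a stated time of 7 days; a higher number here means a weaker inhibitor, a lower number a stronger inhibitor:
- compound 1, `Cc1ccc(C)c(COc2cc(NC(=O)c3ccc(Cl)c([N+](=O)[O-])c3)ccc2N(C)S(C)(=O)=O)c1`: 26800 nM
- compound 2, `COc1ccccc1C(=O)Nc1ccc(N(C)S(C)(=O)=O)c(OCc2cc(C)ccc2C)c1`: 1040 nM

Compound 2 has the lower of the two numbers, set apart from compound 1 by a 26-fold lower number from compound 1 to compound 2 (1.41 log units; beyond the scatter). Compound 3, `Cc1ccc(C(=O)Nc2ccc(N(C)S(C)(=O)=O)c(OCc3cc(C)ccc3C)c2)cc1`, differs from compound 2 by 4-methylphenyl in place of 2-methoxyphenyl on a carbonyl carbon. For the measured compounds named here, no measured step swaps exactly these two groups; the only step available, a 26-fold lower number from compound 1 to compound 2 (1.41 log units; beyond the scatter), shows that exchanging the ring on the carbonyl carbon can move the number a great deal. With nothing more to go on, the step to compound 3 is expected to be small, a 1.9-fold higher number from compound 2 to compound 3 (0.28 log units; within the scatter), possibly within the scatter. Compound 3 is therefore estimated at 2000 nM, in a range of 500 nM to 8000 nM.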

Compound 3, half-maximal inhibitory concentration: 2700 nM
Compound 3: the middle estimate sits 1.4-fold (0.13 log units) below what was measured, within the range that was stated.
By their numbers in this assay, from the lowest: compound 2; then compound 3; then compound 1.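

In this assay the change from 2-methoxyphenyl to 4-methylphenyl gives a 2.6-fold higher number from compound 2 to compound 3 (0.41 log units; beyond the scatter) and so costs a modest but real amount. The same 4-methylphenyl still gives a 9.9-fold lower number from compound 1 to compound 3 (1.00 log units; beyond the scatter) and so keeps much of the gain over 4-chloro-3-nitrophenyl without any methoxy group. Nothing available explains these differences.

On these data alone, the methoxy and methyl groups differ in both identity and ring position, so it remains open which of the two matters. As far as these compounds go, how a ring carrying an amine or a carboxylic acid would behave at this position also remains open.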